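This account rests on a few compounds, and the source may have more. Where it says the series, first, only, none or still open, it means among the compounds named here.

Compound 1 `CN(C)CCn1cnnc1-c1cc(Oc2ccc(NC(=O)N/N=C/c3cccc(Br)c3)cc2F)ccn1` gives 830 nM in a functional assay on U-87MG ATCC cells (Homo sapiens) for cytotoxicity, read by MTT assay, with a stated time of 72 h (a lower number here means a stronger inhibitor, a higher number a weaker inhibitor), and compound 2 `CN(C)CCn1cnnc1-c1cc(Oc2ccc(NC(=O)N/N=C/c3ccc(Cl)cc3)cc2F)ccn1` gives 1370 nM; the step of a 1.7-fold higher number from compound 1 to compound 2 (0.22 log units; within the scatter) is small. Compound 3 `COc1ccc(/C=N/NC(=O)Nc2ccc(Oc3ccnc(-c4nncn4CCN(C)C)c3)c(F)c2)cc1O` reaches only the limit of this assay, > 100000 nM, which is a bound and not a number. That limit is where one of the three values shown sits (the limit of > 100000 nM in this assay, at which 1 of the 3 values shown sits). The steps into compound 3 are both large: an at least 120-fold higher number from compound 1 to compound 3 (2.08 log units; beyond the scatter) and an at least 72-fold higher number from compound 2 to compound 3 (1.86 log units; beyond the scatter), each from a halogenated phenyl to the 3-hydroxy-4-methoxyphenyl.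

Compound 4 `CN(C)CCn1cnnc1-c1cc(Oc2ccc(NC(=O)N/N=C/c3ccc(O)cc3O)cc2F)ccn1` differs from compound 3 in one place: 2,4-dihydroxyphenyl in place of 3-hydroxy-4-methoxyphenyl on a carbon with a double bond to nitrogen. No measured step bears on this change directly; the only steps shown run from the halophenyls of compound 1 and compound 2 to compound 3, and compound 4 keeps a hydroxylated phenyl rather than returning to either. Since compound 3 stands at the limit, an expected step of an at least 1.2-fold lower number from compound 3 to compound 4 (0.09 log units; that floor lies within the scatter) cannot be anchored on a number. Compound 4 is therefore expected to remain weak in this assay, at about 80000 nM, within 10000 nM to 300000 nM, with a real chance that only a limit is reported.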

Compound 4, half-maximal inhibitory concentration: 15400 nM
The estimate for compound 4 lay 5.2-fold (0.72 log units) above the measured number, and the stated range covers the measured number.
By their numbers in this assay, from the lowest: compounds 1 and 2 (each within the scatter of the next); then compound 4. At a limit, above all of these: compound 3.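

On the carbon with a double bond to nitrogen, hydroxylated phenyls do not all behave alike: in this assay, replacing 3-hydroxy-4-methoxyphenyl with 2,4-dihydroxyphenyl gives an at least 6.4-fold lower number from compound 3 to compound 4 (0.81 log units; beyond the scatter). The value of compound 3 is a limit and not a number: the limit of > 100000 nM in this assay, at which 1 of the 4 values shown sits. Compound 4 still does not match either halogenated phenyl, with an 11-fold higher number from compound 2 to compound 4 (1.05 log units; beyond the scatter) and a 19-fold higher number from compound 1 to compound 4 (1.27 log units; beyond the scatter), so a hydroxylated phenyl here can give a measurable number, though a much higher one than in the two halogenated compounds.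

The compounds shown do not separate the loss of the methoxy group from the change in where the hydroxyl groups sit. They also leave open how a phenyl carrying an amine or a carboxylic acid would compare at this place.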